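A few compounds are considered here, and "the series" means these few. Any claim that something is new, unique, unknown or untested is made for them only; others in the source may bear on it.

The shared core of this small set is seen in compound 1 `Fc1ccc(Cn2ccc3nc(-c4ccccc4)nc-3c2)cc1`. For the measured compounds named here, in an ADME assay on MDBK cells (Bos taurus) for cytotoxicity (a lower number here means that less compound is tolerated, a higher number that more compound is tolerated), compound 1 gives > 100000 nM, which is a limit of the assay rather than a number, and compound 1 is the one value that sits at the limit of > 100000 nM in this assay, at which 1 of the 3 values shown sits. Compound 2 `CC(C)(C)c1ccc(Cn2ccc3nc(-c4ccccc4)nc-3c2)cc1` gives 22000 nM in this assay, and compound 3 `c1ccc(-c2ccc(Cn3ccc4nc(-c5ccccc5)nc-4c3)cc2)cc1` gives 18000 nM. The step of an at least 4.5-fold lower number from compound 1 to compound 2 (0.65 log units; beyond the scatter) and the step of an at least 5.5-fold lower number from compound 1 to compound 3 (0.74 log units; beyond the scatter) both run toward a lower number, while the pair a 1.2-fold lower number from compound 2 to compound 3 (0.09 log units; within the scatter) shows no difference beyond the scatter.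

Compound 4 `Clc1ccc(Cn2ccc3nc(-c4ccccc4)nc-3c2)cc1Cl` has not yet been measured in this assay. It differs from compound 1 in one place: 3,4-dichlorophenyl in place of 4-fluorophenyl on a saturated chain carbon bound to an aromatic nitrogen. Both measured steps from compound 1, which put tert-butyl or phenyl in place of fluoro, lowered the number, so a step in the same direction, though perhaps smaller, is expected for compound 4, namely an at least 2.5-fold lower number from compound 1 to compound 4 (0.39 log units; beyond the scatter). Compound 4 is therefore estimated at 40000 nM in this assay, with a range from 15000 nM to 120000 nM.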

Compound 4, half-maximal cytotoxic concentration: 71000 nM
Beside the measured number, compound 4's estimate is 1.8-fold (0.25 log units) below it; measured number inside the range.
By their numbers in this assay, from the lowest: compounds 3 and 2 (each within the scatter of the next); then compound 4. At a limit, above all of these: compound 1.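

The change to 3,4-dichlorophenyl gives an at least 1.4-fold lower number from compound 1 to compound 4 (0.14 log units; that floor lies within the scatter) in this assay, so, unlike the steps to tert-butyl and phenyl, it does not on its own establish a real fall in the number. As far as these compounds go, the true size of this step stays unknown because compound 1 carries a limit and not a number: the limit of > 100000 nM in this assay, at which 1 of the 4 values shown sits. For the compounds shown here, compound 4 adds something the earlier compounds did not cover, a ring with two chlorine atoms at this position on the saturated chain carbon, and it yields a measured number rather than a limit.

The compounds shown leave open whether 4-chlorophenyl, with a single chlorine, would read like compound 4 or like compound 1. They also leave open how an amine or a carboxylic acid on this ring would read in this assay.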